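The source may hold more compounds than are shown below. What is called first, only, known or untested is meant among the compounds shown, and "the series" means these compounds.

In a functional assay on SMA cells (Homo sapiens) for inhibition, read by MTT assay, with a stated time of 72 h (on this read-out lower numbers stand for stronger inhibition of growth and higher numbers for weaker inhibition of growth), compound 1 `N#C/C(=C\c1c(F)c(F)c(F)c(F)c1F)C(=O)c1ccc[nH]1` gives only a limit of the assay, > 100000 nM, and no number. Compound 2 `N#C/C(=C\c1c(F)c(F)c(F)c(F)c1F)C(=O)c1c[nH]c2ccccc12` gives 20000 nM in this assay. Compound 3 `COc1ccc(CNC(=O)/C(C#N)=C/c2ccc[nH]2)cc1` likewise gives only a limit in this assay, > 50000 nM. Compound 3 therefore stands where no number is available: its value is the limit described by the limit of > 50000 nM in this assay, at which 1 of the 3 values shown sits, and the other limit among the three values, (the limit of > 100000 nM in this assay, at which 1 of the 3 values shown sits), belongs to compound 1, so only compound 2 has a measured number at all.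

Compound 4 `COc1ccc(CNC(=O)/C(C#N)=C/c2ccc(C)cc2)cc1` is not yet measured. It differs from compound 3 by 4-methylphenyl in place of 1H-pyrrol-2-yl on a double-bonded chain carbon bound to a double-bonded chain carbon. Among the compounds with values here, no step between measured compounds is recorded, and none of the three values shown involves a 4-methylphenyl group, so the change has no measured counterpart here. Compound 3 stands at a limit, so the step that the limit leaves unreadable from compound 3 to compound 4 that is expected cannot be anchored to a number; the expectation is for no step beyond the scatter, with a limit again the most likely outcome. Compound 4 is expected to give about 60000 nM in this assay, with a range from 20000 nM to 200000 nM.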

Compound 4, concentration for 50% growth inhibition: 42000 nM
Beside the measured number, compound 4's estimate is 1.4-fold (0.15 log units) above it, within the range that was stated.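

Within the data shown here, the result gives the first reading at this position on the shared core, where the earlier compounds offered no number to compare. In this assay, 4-methylphenyl in place of 1H-pyrrol-2-yl on a double-bonded chain carbon bound to a double-bonded chain carbon gives an at least 1.1-fold lower number from compound 3 to compound 4 (0.07 log units; that floor lies within the scatter). This step is only a floor, and its true size stays unknown, because compound 3 gives a limit and no number: the limit of > 50000 nM in this assay, at which 1 of the 4 values shown sits.

What the result does show is that a measured number on this core does not depend on the ring that leaves or on its hydrogen-bond donor, since compound 4 carries a six-membered aromatic ring of carbon only and no donor in that group. The compounds shown leave open how much of the step, if any, belongs to the change of ring and how much to the methyl group, which a plain phenyl ring on the same carbon would separate, and whether an amine or a carboxylic acid in place of that methyl group would move the number in either direction.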